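Replacing 3,4-dimethoxyphenyl with 4-bromophenyl in compound 2

The source may report more compounds than this note shows. Statements on the series, on what has been measured and on what is new or still open speak of the compounds shown alone.

Measured in a functional assay on the whole organism (strain Kunming) with Mus musculus as the target, with a stated time of 0.5 h; on this read-out lower numbers stand for an effect already at smaller amounts and higher numbers for an effect only at larger amounts of compound:
Compound 1 `COc1ccccc1/C=C/C(=O)OC/C=C/c1cc(OC)c(OC)cc1OC`: 101 umol/kg
Compound 2 `COc1cc(OC)c(OC)cc1/C=C/COC(=O)/C=C/c1ccc(OC)c(OC)c1`: 140 umol/kg
Compound 3 `COc1cc(OC)c(OC)cc1/C=C/COC(=O)/C=C/c1c(OC)ccc(OC)c1OC`: 120 umol/kg

Compound 2, at 140 umol/kg, lies within the usual scatter of both compound 1 and compound 3. The change to compound 4 `COc1cc(OC)c(OC)cc1/C=C/COC(=O)/C=C/c1ccc(Br)cc1` is 4-bromophenyl in place of 3,4-dimethoxyphenyl on a double-bonded chain carbon bound to a double-bonded chain carbon. For the measured compounds named here, the one measured step at this place, a 1.4-fold higher number from compound 1 to compound 2 (0.14 log units; within the scatter), stayed within the scatter. Compound 3, with a different group there, gives 120 umol/kg. Going by the values given here, no measured compound carries 4-bromophenyl, so this evidence is indirect and the expected range is wide. The estimated change is a 1.1-fold lower number from compound 2 to compound 4 (0.05 log units; within the scatter), with no shift expected beyond the scatter. For compound 4 the estimated value is 125 umol/kg, with an expected range of 60 umol/kg to 260 umol/kg.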

Compound 4, dose for half-maximal effect: 143 umol/kg
The estimate for compound 4 lay 1.1-fold (0.06 log units) below the measured number; measured number inside the range.
By their numbers in this assay, from the lowest: compounds 1, 3, 2 and 4 (each within the scatter of the next).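

In this assay, the aromatic ring at this place can lose its methoxy groups and carry bromine without a shift beyond the scatter, as the steps show (a 1.0-fold higher number from compound 2 to compound 4 (0.01 log units; within the scatter) and a 1.4-fold higher number from compound 1 to compound 4 (0.15 log units; within the scatter)). The ring without hydrogen-bond acceptors thus reads the same as those with them, so this place has shown no sensitivity to these ring changes so far. No supporting measurement is available to explain this result. Still open, going by these compounds, is whether a ring carrying an amine or a carboxylic acid, or a longer chain in place of the ring, would stay within the scatter too.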